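Fluorophenyl series: ester versus acid, triazole versus isoxazole

This account rests on a few compounds, and the source may have more. Where it says the series, first, only, none or still open, it means among the compounds named here.

Compound 1 `CCOC(=O)C1=Cc2ccccc2OC1(OCc1cn(-c2ccc(F)cc2)nn1)C(F)(F)F` carries the ethyl ester and a triazole bearing a 4-fluorophenyl group. In a functional assay on MCF7 cells (Homo sapiens) for inhibition, read by MTT assay, with a stated time of 24 h (a lower number here means a stronger inhibitor, a higher number a weaker inhibitor), compound 1 gives 9100 nM. Compound 2 `CCOC(=O)C1=Cc2ccccc2OC1(OCc1cn(-c2ccccc2)nn1)C(F)(F)F` differs from it by hydrogen in place of fluoro on an aromatic carbon. For compound 2 only a limit is recorded in this assay, namely > 150000 nM. The step of an at least 16-fold higher number from compound 1 to compound 2 (1.21 log units; beyond the scatter) is read against (the limit of > 150000 nM in this assay, at which 2 of the 3 values shown sit).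

Compound 3 `O=C(O)C1=Cc2ccccc2OC1(OCc1cc(-c2ccc(F)cc2F)no1)C(F)(F)F` holds the free acid and an isoxazole bearing a 2,4-difluorophenyl group; the difference between its core and the core of compound 1 is not broken down here. For compound 3 in this assay only a limit is recorded, > 150000 nM.

Compound 4 `O=C(O)C1=Cc2ccccc2OC1(OCc1cc(-c2ccc(F)cc2)no1)C(F)(F)F` is yet to be measured and differs from compound 3 by hydrogen in place of fluoro on an aromatic carbon. This is the same kind of change as from compound 1 to compound 2, but the place differs: in compound 1 the leaving fluoro sits para to a large group, whereas in compound 3 it sits ortho to a large group and meta to a fluoro group. Given that the step of an at least 16-fold higher number from compound 1 to compound 2 (1.21 log units; beyond the scatter) gave a higher number and that compound 3 shows only a limit, compound 4 is expected to stay at or beyond that limit, which means an expected step that the limit leaves unreadable from compound 3 to compound 4. Compound 4 is estimated at 300000 nM in this assay, between 80000 nM and 1500000 nM.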

Compound 4, half-maximal inhibitory concentration: 64200 nM
The estimate for compound 4 lay 4.7-fold (0.67 log units) above the measured number; the measured number lies below the stated range.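

In this assay, the change from 2,4-difluorophenyl to 4-fluorophenyl gives an at least 2.3-fold lower number from compound 3 to compound 4 (0.36 log units; beyond the scatter), so hydrogen in place of fluoro does not carry over from one core to the other with the same result: the same change on two cores in this assay, an at least 16-fold higher number (1.21 log units; beyond the scatter) from compound 1 to compound 2 and an at least 2.3-fold lower number (0.36 log units; beyond the scatter) from compound 3 to compound 4, at least 38-fold (1.58 log units) apart, beyond the scatter of two such steps

Each of the two steps has a limit at one end, so each gives only a bound on its size, not an exact size: the limit of > 150000 nM in this assay, at which 2 of the 4 values shown sit.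

These pairs do not show what sets the direction of the step, since the ester and acid, the triazole and isoxazole, and the place of the fluoro that leaves all differ together between them.

Still open, going by these compounds, is how the free acid reads on the triazole and how the ethyl ester reads on the isoxazole, either of which would separate these differences. Also open, on these data alone, is how a chloro or methoxy group on the phenyl ring, in place of fluoro, would read in this assay.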